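From Chloro to Fluoro: Expecting the Next Growth-Inhibition Number

The compounds below may be only part of what the source reports. "The series", "measured", "known", "first", "only" and "open" are said of these compounds alone.

Of the compounds shown here, two have so far been measured in a functional assay on SK-OV-3 cells (Homo sapiens) for inhibition, read by sulforhodamine B assay, with a stated time of 48 h; a higher number here means a weaker inhibitor of growth, a lower number a stronger inhibitor of growth. Compound 1 `COc1ccc(-c2ccc(-c3ccc(C(=N)N)o3)o2)cc1` gives 5630 nM in this assay. Compound 2 `N=C(N)c1ccc(-c2ccc(-c3ccc(Cl)cc3)s2)s1` gives 1700 nM in this assay, the lowest of the two numbers; compound 1 stands at a higher number, and that gap lies beyond the usual scatter of the measurement. Compound 3 `N=C(N)c1ccc(-c2ccc(-c3ccc(F)cc3)s2)s1` has not yet been measured. It differs from compound 2 in a single place: fluoro in place of chloro on an aromatic carbon. Among the compounds with values here, no pair of measured compounds shows what this exchange does here, so there is no measured step to lean on. The exchange is small in size, and the expectation is that it moves the number only a little, perhaps slightly upward toward a weaker inhibitor of growth, most likely staying within the scatter. Compound 3 is therefore estimated at 2500 nM, with a range from 1000 nM to 6500 nM. This corresponds to an expected step of a 1.5-fold higher number from compound 2 to compound 3 (0.17 log units; within the scatter).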

Compound 3, concentration for 50% growth inhibition: 1800 nM
Beside the measured number, compound 3's estimate is 1.4-fold (0.14 log units) above it; the range from low to high includes it.
By their numbers in this assay, from the lowest: compounds 2 and 3 (each within the scatter of the next); then compound 1.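

In this assay, moving to fluoro in place of chloro at this position, on the six-membered aromatic ring and para to a large group, gives a 1.1-fold higher number from compound 2 to compound 3 (0.02 log units; within the scatter) and so stays within the scatter. Within the data shown here, this is the first measured step between two compounds that differ in one place, and it shows that this exchange leaves no readable mark on the growth-inhibition number. Nothing measured here explains why the two halogens read alike.

As far as these compounds go, an amine, a carboxylic acid or a longer chain such as butyl at this same position remains open, and one such group could show whether the position responds to a larger change. Compound 1 differs from compound 2 in more than one place, so the gap between them cannot be assigned to any single change.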